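The compounds below may be only part of what the source reports. "The series", "measured", "known", "first", "only" and "open" are said of these compounds alone.

Compound 2 `N#Cc1ccc(Nc2nccc(SC3CCCCC3)n2)cc1` shows in an ADME assay on MT4 cells (Homo sapiens) for cytotoxicity, read by MTT assay (a higher number here means that more compound is tolerated, a lower number that less compound is tolerated), only a limit, > 402000 nM (the limit of > 402000 nM in this assay, at which 1 of the 3 values shown sits). Compound 3 `Cc1cc(SC2CCCCC2)nc(Nc2ccc(C#N)cc2)n1` likewise gives only a limit in this assay, >= 192000 nM (the limit of >= 192000 nM in this assay, at which 1 of the 3 values shown sits). The step that the two limits leave unreadable from compound 2 to compound 3 therefore cannot be read. Compound 1 `Cc1cnc(Nc2ccc(C#N)cc2)nc1OC1CCCCC1` gives a number in this assay, 31200 nM. Compound 4 `N#Cc1ccc(Nc2nccc(OC3CCCC3)n2)cc1` is the change (cyclopentyloxy in place of cyclohexylsulfanyl on an aromatic carbon). For the measured compounds named here, no measured step covers this change, and the single measured step is unreadable, so no size can be carried over. Compound 1 carries an oxygen-linked ring and gives 31200 nM. On that basis the step of an at least 5.7-fold lower number from compound 2 to compound 4 (0.75 log units; beyond the scatter) is estimated to run toward more cytotoxicity. Compound 4 is therefore expected at 70000 nM, between 20000 nM and 300000 nM.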

Compound 4, half-maximal cytotoxic concentration: >= 339000 nM
Compound 4 was reported as a limit (the forecaster's own chance of this, stated with the estimate: 35%); middle value at least 4.8-fold (0.68 log units) from the limit.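

Compound 2 and compound 4 are both reported only as limits, so the step between them cannot be read. The compounds shown leave open the size and direction of any change on replacing cyclohexylsulfanyl with cyclopentyloxy.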